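The compounds below may be only part of what the source reports. "The series", "measured", "known", "first", "only" and "open" are said of these compounds alone.

Of the compounds shown here, three have so far been measured in an assay on cells for inhibition of cytochrome P450 11B2, mitochondrial (Homo sapiens), read by HTRF; on this read-out higher numbers stand for weaker inhibition and lower numbers for stronger inhibition. Compound 2 `CC(=O)N[C@@H]1CCCc2c1cncc2N1C(=O)c2ccc(Cl)cc2[C@@H]1C` gives 4 nM, while compound 1 `CC(=O)N[C@@H]1CCCc2c1cncc2N1C(=O)c2ccc(Cl)cc2[C@@H]1C1CC1` gives 354 nM; the step of an 89-fold higher number from compound 2 to compound 1 (1.95 log units; beyond the scatter) arises from a single change, (cyclopropyl in place of methyl on a saturated ring carbon). The core of compound 3 `CC1c2cc(Cl)ccc2C(=O)N1c1cccnc1` differs from that of compound 2 in a way not broken down here. In this assay compound 3 gives 123 nM. Compound 4 `O=C1c2ccc(Cl)cc2C(C2CC2)N1c1cccnc1` has not yet been measured; it differs from compound 3 by cyclopropyl in place of methyl on a saturated ring carbon. This is the same kind of change as that from compound 2 to compound 1, though not the same: in compound 3 the ring atom beside the altered carbon bears a pyridin-3-yl group, whereas in compound 2 it bears a large group. A large step is expected for compound 4 because the earlier change gave an 89-fold higher number from compound 2 to compound 1 (1.95 log units; beyond the scatter), with some doubt because compound 3 already gives 123 nM on a different core. Compound 4 is expected to give about 3500 nM, between 800 nM and 15000 nM, an estimated step of a 28-fold higher number from compound 3 to compound 4 (1.45 log units; beyond the scatter).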

Compound 4, half-maximal inhibitory concentration: 161 nM
Compound 4: the middle estimate sits 22-fold (1.34 log units) above what was measured; measured number outside the range, below it.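

In this assay, putting cyclopropyl in place of methyl on the saturated ring carbon gives a 1.3-fold higher number from compound 3 to compound 4 (0.12 log units; within the scatter). The same change therefore does not carry over at a constant size between the two cores: the same change on two cores in this assay, an 89-fold higher number (1.95 log units; beyond the scatter) from compound 2 to compound 1 and a 1.3-fold higher number (0.12 log units; within the scatter) from compound 3 to compound 4, 68-fold (1.83 log units) apart, beyond the scatter of two such steps. Among these compounds, the large step seen on the core of compound 2 thus cannot be assumed on another core, but with only one pair on each core, this does not show which difference between the cores sets the size of the step.

On these data alone, it remains open how an ethyl or isopropyl group on that saturated ring carbon would behave on either core. As far as these compounds go, it is also open whether either of these groups would give a large step on both cores or only on one.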